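Chloro in Place of Fluoro: Expected Cytotoxicity of Compound 4

The source may report more compounds than this note shows. Statements on the series, on what has been measured and on what is new or still open speak of the compounds shown alone.

Compound 2 `Cc1cc(NC(=O)Nc2cccc(F)c2)c2ccccc2n1` is one of three measured members of this series, alongside compound 1 `Cc1cc(NC(=O)Nc2ccc(F)c(F)c2)c2ccccc2n1` and compound 3 `Cc1cc(NC(=O)Nc2cc(F)ccc2F)c2ccccc2n1`. In an ADME assay on HEK293 cells (Homo sapiens) for cytotoxicity, with a stated time of 72 h (on this read-out higher numbers stand for an effect only at larger amounts of compound and lower numbers for an effect already at smaller amounts), compound 2 gives only a limit, > 25000 nM. Compound 1 likewise gives only a limit, > 25000 nM. Compound 3 gives 12000 nM. The step that the two limits leave unreadable from compound 1 to compound 2 cannot be read, whereas the step of an at least 2.0-fold lower number from compound 2 to compound 3 (0.31 log units; beyond the scatter) is readable; two of the three values sit at the limit of > 25000 nM in this assay, at which 2 of the 3 values shown sit. Compound 4 `Cc1cc(NC(=O)Nc2cccc(Cl)c2)c2ccccc2n1` differs from compound 2 by chloro in place of fluoro on an aromatic carbon. Going by the values given here, neither measured step concerns a chlorine, so no step of known size bears directly on this change, and compound 2 itself stands at a limit. Compound 4 is therefore expected to stay near that limit, the expected step being a number no higher from compound 2 to compound 4 (the limit leaves the size open). Compound 4 is estimated at 25000 nM in this assay, with a range from 10000 nM to 60000 nM.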

Compound 4, half-maximal effective concentration: 21000 nM
The estimate for compound 4 lay 1.2-fold (0.08 log units) above the measured number; the measured number falls inside the stated range.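

With chloro in place of fluoro on this aromatic carbon, this assay shows an at least 1.1-fold lower number from compound 2 to compound 4 (0.07 log units; that floor lies within the scatter), so the change brings no readable shift. Compound 4 does, however, give this series a measured number for a single halogen at this place, which the 3-fluorophenyl compound could not provide. Compound 2 stands at a limit, so only a floor can be read for this step: the limit of > 25000 nM in this assay, at which 2 of the 4 values shown sit.

On these data alone, the true size of the step therefore remains open. So does how an amine or a carboxylic acid on this carbon would read in this assay.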